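Swapping an Acylpiperidine Amide for a Triazolylmethyl Urea

The source may hold more compounds than are shown below. What is called first, only, known or untested is meant among the compounds shown, and "the series" means these compounds.

Compound 1 `CC(C)C(=O)N1C[C@@H](O[C@H](C)c2cc(C(F)(F)F)cc(C(F)(F)F)c2)[C@H](c2ccc(F)cc2)C1` gives 0.15 nM in an assay on CHO cells for displacement of a labelled ligand from Substance-P receptor (Homo sapiens); a lower number here means a stronger inhibitor, a higher number a weaker inhibitor.
Compound 2 `CC(=O)N1CCC(C(=O)N2C[C@@H](O[C@H](C)c3cc(C(F)(F)F)cc(C(F)(F)F)c3)[C@H](c3ccc(F)cc3)C2)CC1` gives 0.07 nM.
Compound 3 `CCNC(=O)N1C[C@@H](O[C@H](C)c2cc(C(F)(F)F)cc(C(F)(F)F)c2)[C@H](c2ccc(F)cc2)C1` gives 0.1 nM.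

Compound 2 has the lowest of the three numbers, but only its gap to compound 1 lies beyond the scatter; the other gap, a 1.4-fold higher number from compound 2 to compound 3 (0.15 log units; within the scatter), lies within it. Compound 4 `C[C@@H](O[C@@H]1CN(C(=O)NCc2cn[nH]n2)C[C@H]1c1ccc(F)cc1)c1cc(C(F)(F)F)cc(C(F)(F)F)c1` differs from compound 2 in one place: ((2H-1,2,3-triazol-4-yl)methyl)amino in place of 1-acetylpiperidin-4-yl on a carbonyl carbon. Within the data shown here, two measured steps bear on this change, a 1.5-fold lower number from compound 1 to compound 3 (0.18 log units; within the scatter) and a 1.4-fold higher number from compound 2 to compound 3 (0.15 log units; within the scatter), both within the scatter: putting an amino group on that carbonyl carbon has so far moved the number little. For compound 4 the expected step is therefore a 1.4-fold higher number from compound 2 to compound 4 (0.15 log units; within the scatter), not beyond the scatter. The estimate for compound 4 in this assay is 0.1 nM, with a range from 0.04 nM to 0.3 nM.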

Compound 4, half-maximal inhibitory concentration: 0.58 nM
Beside the measured number, compound 4's estimate is 5.8-fold (0.76 log units) below it, outside the stated range (above it).
By their numbers in this assay, from the lowest: compounds 2, 3 and 1 (each within the scatter of the next, the first and the last beyond it); then compound 4.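

Keeping the urea and putting 2H-1,2,3-triazol-4-yl in place of the methyl of the ethylamino group gives a 5.8-fold higher number from compound 3 to compound 4 (0.76 log units; beyond the scatter) in this assay, so an amino group on that carbonyl carbon does not by itself leave the number unchanged. Against the two amides the new group gives an 8.3-fold higher number from compound 2 to compound 4 (0.92 log units; beyond the scatter) and a 3.9-fold higher number from compound 1 to compound 4 (0.59 log units; beyond the scatter) and places compound 4 highest of the four numbers. Nothing available explains this rise. From the compounds shown here alone, whether it belongs to the triazole or to any ring on that chain stays open, and a phenyl group in the triazole's place would help to separate the two.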